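Swapping benzoyl for ethyl on an amine nitrogen

This account rests on a few compounds, and the source may have more. Where it says the series, first, only, none or still open, it means among the compounds named here.

- compound 1 `C/C=C(/C)C(=O)OC(C)c1cc2c(cc1OC)OC(C)(C)C=C2` gives 139000 nM
- compound 2 `COc1cc2c(cc1C(C)NC(=O)c1ccccc1)C=CC(C)(C)O2` gives 34800 nM
- compound 3 `COc1cc2c(cc1C(C)N[C@H](C)c1ccccc1)C=CC(C)(C)O2` gives 15900 nM

In an ADME assay on L6 cells (Rattus norvegicus) for cytotoxicity (on this read-out higher numbers stand for weaker inhibition and lower numbers for stronger inhibition), compound 2 gives 34800 nM as the second highest of the three numbers, lower than compound 1 and higher than compound 3. The next compound to be tested is compound 4 `CCNC(C)c1cc2c(cc1OC)OC(C)(C)C=C2` and it differs from compound 2 in one place: ethyl in place of benzoyl on an amine nitrogen with ethyl in place of benzoyl on an amine nitrogen.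

Among the measured compounds shown here, one measured step bears on this change. Going by a 2.2-fold lower number from compound 2 to compound 3 (0.34 log units; beyond the scatter) with 1-phenylethyl in place of benzoyl on an amine nitrogen, a modest step beyond the scatter, a similar modest move to a lower number is expected in this assay for the new compound. This is thin support, since it is a single step and ethyl, unlike 1-phenylethyl, has no ring. The estimated step is a 1.6-fold lower number from compound 2 to compound 4 (0.20 log units; within the scatter) in this expectation. Compound 4 is expected at 22000 nM with a range from 8000 nM to 60000 nM as the estimate.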

Compound 4, half-maximal inhibitory concentration: 176000 nM
The estimate for compound 4 lay 8.0-fold (0.90 log units) below the measured number; measured number outside the range, above it.
By their numbers in this assay, from the lowest: compound 3; then compound 2; then compounds 1 and 4 (each within the scatter of the next).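

In this assay, the group on the amine nitrogen matters, but not every replacement of benzoyl moves the number the same way: ethyl in its place gives a 5.1-fold higher number from compound 2 to compound 4 (0.70 log units; beyond the scatter), the opposite direction to the step seen with 1-phenylethyl. Taking only the phenyl off the 1-phenylethyl group gives an 11-fold higher number from compound 3 to compound 4 (1.04 log units; beyond the scatter), the largest step so far, so in this pair the phenyl ring goes with the lower number. Ethylamino in place of ((1-methylprop-1-en-1-yl)carbonyl)oxy gives a 1.3-fold higher number from compound 1 to compound 4 (0.10 log units; within the scatter), which is within the scatter, so these two compounds cannot be told apart here.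

Nothing at hand gives a cause for these steps. Open, as far as these compounds go, is whether a benzyl group or a longer chain such as butyl on the amine nitrogen would behave like ethyl or like 1-phenylethyl.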